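Bromo on the hydroxy-bearing ring of compound 3

The source may hold more compounds than are shown below. What is called first, only, known or untested is meant among the compounds shown, and "the series" means these compounds.

Measured so far in a functional assay on PC-3 cells (Homo sapiens) for antiproliferative activity, read by MTT assay, with a stated time of 96 h; on this read-out lower numbers stand for stronger inhibition of growth and higher numbers for weaker inhibition of growth

- compound 1 `c1ccc(Nc2ccc3ccccc3n2)nc1` gives > 30000 nM as a limit of the assay
- compound 2 `Clc1ccnc(Nc2ccc3ccccc3n2)c1` gives > 30000 nM as a limit of the assay
- compound 3 `Oc1cccc2ccc(Sc3ccccn3)nc12` gives 20900 nM as a number

Among the compounds with values here, compound 3 holds the only number. Compound 1 and compound 2 mark the limit of > 30000 nM in this assay, at which 2 of the 3 values shown sit, and give no readable value.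

Next is compound 4 `Oc1ccc(Br)c2ccc(Sc3ccccn3)nc12`, which differs from compound 3 by bromo in place of hydrogen on an aromatic carbon with bromo in place of hydrogen on an aromatic carbon, para to a hydroxy group. Within the data shown here, the one measured step of a similar kind is a step that the two limits leave unreadable from compound 1 to compound 2, where chloro replaces hydrogen on an aromatic carbon. Among the measured compounds shown here, that step sits on another core and gives no size, so no measured step sets the size expected here.

Compound 3 at 20900 nM leaves little room on the weak side of the readable range. A clearly weaker result for compound 4 would therefore probably be reported only as a limit. As far as these compounds go, a modest gain in growth inhibition is expected as slightly more likely, though a step within the scatter remains open. The expected change is a 1.7-fold lower number from compound 3 to compound 4 (0.24 log units; within the scatter) in this assay and stays a rough estimate. For compound 4 the estimated value is 12000 nM with 3500 nM to 30000 nM as the expected range.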

Compound 4, concentration for 50% growth inhibition: 10200 nM
Estimate against measurement, compound 4: 1.2-fold (0.07 log units) above, and the stated range covers the measured number.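

In this assay, bromo in place of hydrogen on an aromatic carbon, para to a hydroxy group, gives a 2.0-fold lower number from compound 3 to compound 4 (0.31 log units; beyond the scatter), a modest step and the only readable one in the series. Within the data shown here, it shows that this carbon of the shared core accepts a bromo with a gain in growth inhibition rather than a loss, a direction that the earlier compounds could not give for any halogen. The chloro step on the core of compound 1 cannot be read, so the size found here has no measured counterpart on that core, and the series still has few readable values: the limit of > 30000 nM in this assay, at which 2 of the 4 values shown sit.

As far as these compounds go, whether a chloro, a methoxy group or an amine on this same carbon would move the number as far as bromo does stays open. Also open, from the compounds shown here alone, is whether the step holds with a methoxy group in place of the hydroxy group, and whether bromo on another carbon of the same ring gives a step of similar size.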